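Naphthyloxyacetyl hydrazones: bromo to methyl on the aryl ring

A few compounds are considered here, and "the series" means these few. Any claim that something is new, unique, unknown or untested is made for them only; others in the source may bear on it.

Measured so far:
compound 1 `C/C(=N\NC(=O)COc1cccc2ccccc12)c1ccccc1`, 3.65
compound 2 `O=C(COc1cccc2ccccc12)N/N=C/c1ccc(Br)cc1`, 4.81

Two compounds of the series have been run in a physicochemical assay for lipophilicity, measured as octanol-water partition; on this read-out lower numbers stand for lower lipophilicity and higher numbers for higher lipophilicity. Compound 1 `C/C(=N\NC(=O)COc1cccc2ccccc12)c1ccccc1` gives 3.65. Compound 2 `O=C(COc1cccc2ccccc12)N/N=C/c1ccc(Br)cc1` gives 4.81, the higher of the two numbers; the gap to compound 1 is beyond the scatter, so compound 2 stands as the higher of the pair in this assay. Going by the values given here, no single-change step between these two has been worked out, so only the two values themselves are compared here.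

Compound 3 `Cc1ccc(/C=N/NC(=O)COc2cccc3ccccc23)cc1` has not yet been measured. It differs from compound 2 in one place: methyl in place of bromo on an aromatic carbon. No measured step covers a change of this kind in the series, so the expectation rests on compound 2 alone. The expected step is a number 0.31 log units lower from compound 2 to compound 3 (beyond the scatter), a small move downward, within the scatter. Compound 3 is estimated at 4.5, with a range from 4.1 to 4.9.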

Compound 3, partition coefficient: 4.49
For compound 3 the middle estimate is 0.01 log units above the measured one; the range from low to high includes it.
By their numbers in this assay, from the lowest: compound 1; then compound 3; then compound 2.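

In this assay, methyl in place of bromo on an aromatic carbon, para to a large group, gives a number 0.32 log units lower from compound 2 to compound 3 (beyond the scatter), the first single-change step available in the series and a modest one. It shows that this position responds to the exchange of 4-bromophenyl for 4-methylphenyl, although one heavy atom replaces one heavy atom and neither group adds hydrogen-bond donors, acceptors or net charge. No measurement here accounts for the size or direction of this step.

A single exchange at this position leaves open how far an amine, a carboxylic acid or a longer chain there would move the number, and in which direction. Compound 1 differs from compound 2 and compound 3 in more than one place, so the separate contributions of its differences remain unresolved.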